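The source may hold more compounds than are shown below. What is called first, only, known or untested is meant among the compounds shown, and "the series" means these compounds.

The account rests on a physicochemical assay for solubility, in phosphate buffer, with a stated time of 18 h, at pH 7.4 (a lower number here means a less soluble compound, a higher number a more soluble compound), and on two measured compounds that share a core. Compound 1 (`Nc1nc(-c2ccccn2)nn1-c1ncnc2ccccc12`) reads 9000 nM there. Compound 2 (`CCN(CC)c1nc(-n2nc(-c3ccccn3)nc2N)c2cc(OC)c(OC)cc2n1`) reads 6000 nM on the same scale, so the two values lie within the scatter of each other and neither can be set apart from the other.

Compound 3 (`COc1cc2nc(-c3ccccc3)nc(-n3nc(-c4ccccn4)nc3N)c2cc1OC`) has not yet been measured. It departs from compound 2 at a single place, with phenyl in place of diethylamino on an aromatic carbon, between two ring nitrogen atoms (phenyl in place of diethylamino on an aromatic carbon). Within the data shown here, no measured pair shows a change of this kind, so the data offer no step to carry over. The expectation therefore rests on the structural change alone and stays loose. A modest fall in this assay is expected, somewhat beyond the scatter. The estimated step is a 2.4-fold lower number from compound 2 to compound 3 (0.38 log units; beyond the scatter) and it carries wide uncertainty. Compound 3 is estimated at 2500 nM with an expected range from 600 nM to 8000 nM once the measurement is made.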

Compound 3, solubility: 2000 nM
Beside the measured number, compound 3's estimate is 1.3-fold (0.10 log units) above it; the range from low to high includes it.
By their numbers in this assay, from the lowest: compound 3; then compounds 2 and 1 (each within the scatter of the next).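

In this assay, among these compounds, the aromatic carbon between two ring nitrogen atoms now has a measured step, which the earlier compounds did not provide: phenyl in place of diethylamino gives a 3.0-fold lower number from compound 2 to compound 3 (0.48 log units; beyond the scatter). The reading at this position therefore depends on the group it carries, and the exchange is large enough to stand clear of the usual variation between repeats, though modest in size. The exchange replaces a group with no ring and one hydrogen-bond acceptor with a six-membered aromatic ring of carbon only, but nothing measured here bears on what lies behind the step.

A single step at this place leaves open where other groups there, such as morpholine, dimethylamino or a pyridine ring, would fall relative to compound 2 and compound 3 in this assay. It also leaves open whether phenyl in place of diethylamino would give a step of similar size on a core lacking the two methoxy groups, or whether the step belongs to the core shared by compound 2 and compound 3.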